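Chloro for methoxy in a small series

The source may report more compounds than this note shows. Statements on the series, on what has been measured and on what is new or still open speak of the compounds shown alone.

Compound 1 (`COc1ccc(/C=C/C(=O)/C=C/c2nc3ccccc3n2C)cc1O`) 2900 nM
Compound 2 (`COc1ccc(/C=C/C(=O)/C=C/c2nc3cc(C)ccc3n2C)cc1O`) 3300 nM
Compound 3 (`COc1ccc2c(c1)nc(/C=C/C(=O)/C=C/c1ccc(OC)c(O)c1)n2C`) 4200 nM

In a functional assay on HepG2 cells (Homo sapiens) for cytotoxicity, read by MTT assay, with a stated time of 48 h (on this read-out higher numbers stand for weaker inhibition and lower numbers for stronger inhibition), compound 3 gives 4200 nM and lies within the scatter of both other measured compounds, so no order among the three can be read. The step under consideration leads to compound 4 (`COc1ccc(/C=C/C(=O)/C=C/c2nc3cc(Cl)ccc3n2C)cc1O`), with chloro in place of methoxy on an aromatic carbon. Among the measured compounds shown here, three measured steps bear on it, and all lie within the scatter: methyl in place of hydrogen (a 1.1-fold higher number from compound 1 to compound 2 (0.06 log units; within the scatter)), methoxy in place of hydrogen (a 1.4-fold higher number from compound 1 to compound 3 (0.16 log units; within the scatter)) and methoxy in place of methyl (a 1.3-fold higher number from compound 2 to compound 3 (0.10 log units; within the scatter)). For the measured compounds named here, no chloro compound has been measured, so this evidence is indirect and covers these three compounds only. No step beyond the scatter is therefore expected in this assay, and no direction is favoured. The estimated step is a 1.3-fold lower number from compound 3 to compound 4 (0.10 log units; within the scatter) and is expected to stay within the scatter. Compound 4 is estimated at 3300 nM (expected range 1600 nM to 6500 nM).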

Compound 4, half-maximal inhibitory concentration: 4100 nM
Compound 4: the middle estimate sits 1.2-fold (0.09 log units) below what was measured; the measured number falls inside the stated range.
By their numbers in this assay, from the lowest: compounds 1, 2, 4 and 3 (each within the scatter of the next).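

Chloro at this aromatic carbon of the shared core adds a halogen to the comparison in this assay. Against methoxy the change gives a 1.0-fold lower number from compound 3 to compound 4 (0.01 log units; within the scatter) and against methyl it gives a 1.2-fold higher number from compound 2 to compound 4 (0.09 log units; within the scatter) while against hydrogen it gives a 1.4-fold higher number from compound 1 to compound 4 (0.15 log units; within the scatter) and so hydrogen, methyl, methoxy and chloro at this carbon remain indistinguishable across compound 1, compound 2, compound 3 and compound 4, where the earlier compounds covered only the first three groups. Nothing available explains this flat result.

On these data alone, whether an amine or a carboxylic acid at this carbon would produce a step beyond the scatter remains open. Also open, as far as these compounds go, is whether chloro on another aromatic carbon of the core would behave in the same way.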